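Swapping a piperazine for a fluoropyridine on a shared core

This account rests on a few compounds, and the source may have more. Where it says the series, first, only, none or still open, it means among the compounds named here.

Of the compounds shown here, two have been measured in a physicochemical assay for lipophilicity; a lower number here means a more polar compound, a higher number a more lipophilic compound. Compound 1, `O=S(=O)(Nc1ccncn1)c1ccc2c(c1)OCC[C@@H]2c1ccc(C(F)(F)F)cc1-c1ccc(F)cn1`, gives 3 in this assay. Compound 2, `O=S(=O)(Nc1nccs1)c1ccc2c(c1)OCC[C@@H]2c1ccc(C(F)(F)F)cc1N1CCNCC1`, gives 1.4 in this assay, the lowest of the two numbers, with compound 1 standing higher by a gap that lies beyond the usual scatter. Compound 3, `O=S(=O)(Nc1nccs1)c1ccc2c(c1)OCC[C@@H]2c1ccc(C(F)(F)F)cc1-c1ccc(F)nc1`, has not yet been measured. It differs from compound 2 in one place: 6-fluoropyridin-3-yl in place of piperazin-1-yl on an aromatic carbon. The group that leaves carries a hydrogen-bond donor; the group that enters carries none and is aromatic. Because compound 1 carries a fluoropyridine at the same kind of position and gives 3 in this assay, well above compound 2, a clear rise from compound 2 to compound 3 is expected, estimated at a number 1.80 log units higher from compound 2 to compound 3 (beyond the scatter) in this assay. Compound 3 is therefore expected to give about 3.2, within a range of 2.6 to 3.8.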

Compound 3, distribution coefficient: 3.2
Compound 3: middle estimate and measured number agree at the digits printed; low and high end bracket the measured number.
By their numbers in this assay, from the lowest: compound 2; then compounds 1 and 3 (each within the scatter of the next).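

Replacing piperazin-1-yl with 6-fluoropyridin-3-yl gives a number 1.80 log units higher from compound 2 to compound 3 (beyond the scatter) in this assay, so the group at this position, ortho to a large group and meta to a trifluoromethyl group, can move the reading by a large amount. Compounds 1 and 2 differ in more than one place, so they could not isolate this change; compound 2 and compound 3 differ only here, which ties the step to this one swap. Nothing measured here explains the size of the step.

The swap changes the ring type, the hydrogen-bond donor count and the atoms all at once, so the compounds shown cannot say which of these differences matters. Where a piperidine or a plain phenyl ring at this position would fall relative to compound 2 and compound 3 also remains open.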